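Six-membered amide substituents: compound 3 to compound 4

The source may hold more compounds than are shown below. What is called first, only, known or untested is meant among the compounds shown, and "the series" means these compounds.

Compound 1 `CC(C)CN1CCc2nc(C#Cc3ccccc3)sc2C1` carries an isobutyl group on the ring amine; in an assay on HEK293 cells for negative allosteric modulation of metabotropic glutamate receptor 5 (Homo sapiens), read by FLIPR, with a stated time of 1 h (a higher number here means a weaker inhibitor, a lower number a stronger inhibitor), compound 1 gives 650 nM. Compound 2 `O=C(C1CCC1)N1CCc2nc(C#Cc3ccccc3)sc2C1` carries a cyclobutylcarbonyl group instead, and in this assay compound 2 gives 370 nM; the step of a 1.8-fold lower number from compound 1 to compound 2 (0.24 log units; within the scatter) stays within the scatter. Compound 3 `CC1CCC(C(=O)N2CCc3nc(C#Cc4ccccc4)sc3C2)CC1` carries a 4-methylcyclohexyl group on the carbonyl carbon. In this assay compound 3 gives only a limit, > 10000 nM, namely (the limit of > 10000 nM in this assay, at which 1 of the 3 values shown sits). The step of an at least 27-fold higher number from compound 2 to compound 3 (1.43 log units; beyond the scatter) is large and beyond the scatter, so compound 3 stands at the top end of the numbers shown, with only a bound known.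

Compound 4 `O=C(C1CCOCC1)N1CCc2nc(C#Cc3ccccc3)sc2C1` differs from compound 3 by oxan-4-yl in place of 4-methylcyclohexyl on a carbonyl carbon. For the measured compounds named here, only the step from compound 2 to compound 3 bears on this change, and it was large; it exchanged cyclobutyl for 4-methylcyclohexyl, whereas compound 4 keeps a six-membered ring but without the methyl and with one oxygen. Compound 4 is therefore expected to give a lower number in this assay than compound 3, yet not to regain the level of compound 2. The expected step is an at least 3.3-fold lower number from compound 3 to compound 4 (0.52 log units; beyond the scatter). The estimate for compound 4 is 3000 nM, within 700 nM to 12000 nM.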

Compound 4, half-maximal inhibitory concentration: > 10000 nM
Compound 4: only a limit was reported; the forecaster's own chance of this, stated with the estimate: 30%; middle value at least 3.3-fold (0.52 log units) away from the limit.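

In this assay compound 4 gives > 10000 nM, which is a limit and not a number, and the step from compound 3 cannot be read, leaving oxan-4-yl and 4-methylcyclohexyl unranked at this position: the limit of > 10000 nM in this assay, at which 2 of the 4 values shown sit. The loss seen with 4-methylcyclohexyl on the carbonyl carbon persists with neither the methyl nor an all-carbon ring, as shown by an at least 27-fold higher number from compound 2 to compound 4 (1.43 log units; beyond the scatter) for oxan-4-yl in place of cyclobutyl and by an at least 15-fold higher number from compound 1 to compound 4 (1.18 log units; beyond the scatter) for (oxan-4-yl)carbonyl in place of isobutyl on the ring amine nitrogen. Among the compounds shown, both six-membered non-aromatic rings on this carbonyl carbon sit at the limit, whether of carbon only or with one hetero atom, while the cyclobutyl of compound 2 does not, and no compound shown goes against this.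

From the compounds shown here alone, whether ring size alone marks the boundary stays open, and cyclopentyl, cyclopropyl or an open chain such as isopropyl on the carbonyl carbon would test it. Going by these compounds, how far compound 3 and compound 4 lie beyond the limit, and whether they differ from each other at all, also stays open.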